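The source may report more compounds than this note shows. Statements on the series, on what has been measured and on what is new or still open speak of the compounds shown alone.

For the measured compounds named here, all three compounds measured so far were read in a functional assay on T47D cells (Homo sapiens) for inhibition, read by sulforhodamine B assay, with a stated time of 48 h; on this read-out lower numbers stand for stronger inhibition of growth and higher numbers for weaker inhibition of growth.

compound 1 `N#C/C(=C\N1CCN(C(=O)c2ccco2)C1=S)C(N)=O`: 9300 nM
compound 2 `N#C/C(=C\N1CCN(C(=O)c2ccco2)C1=S)C(=O)c1ccccc1`: 7200 nM
compound 3 `O=CN1CCN(c2ccc(Cl)cc2)C1=S`: 12800 nM

Compound 3 stands at the highest of the three numbers, yet its gaps to compound 1 and to compound 2 are both within the scatter, so no order among the three can be read from these values. Going by the values given here, the only measured step, a 1.3-fold lower number from compound 1 to compound 2 (0.11 log units; within the scatter), lies within the scatter and concerns the carbonyl substituent of the shared core of compound 1, not the aryl ring that compound 3 carries; it bears on the present change only in showing that one substitution left the number unchanged.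

Compound 4 `O=CN1CCN(c2ccc(Cl)c(Cl)c2)C1=S` differs from compound 3 by chloro in place of hydrogen on an aromatic carbon. Among the compounds with values here, no measured pair shows the effect of a second chloro on this ring, so nothing beyond the scatter is expected: compound 4 is expected to sit close to compound 3, the expected step being a 1.3-fold lower number from compound 3 to compound 4 (0.13 log units; within the scatter). The estimate for compound 4 is 9500 nM, with a range from 3500 nM to 26000 nM.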

Compound 4, concentration for 50% growth inhibition: 15300 nM
The estimate for compound 4 lay 1.6-fold (0.21 log units) below the measured number; measured number inside the range.
By their numbers in this assay, from the lowest: compounds 2, 1, 3 and 4 (each within the scatter of the next, the first and the last beyond it).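

In this assay, chloro in place of hydrogen on an aromatic carbon, ortho to a chloro group and meta to a group of 8 heavy atoms, gives a 1.2-fold higher number from compound 3 to compound 4 (0.08 log units; within the scatter) and so stays within the scatter. For the compounds shown here, this is the first measured change on the aromatic ring of compound 3, and at this place a second chloro leaves the read-out without a step that can be told from the scatter; the one earlier step concerned a carbonyl substituent on the core of compound 1. No measurement given here bears on this result.

Open, from the compounds shown here alone, is whether an amine, a methoxy group or a carboxylic acid at this place would give a step beyond the scatter. Also open, going by these compounds, is how the same chloro would read with a longer chain in place of the formyl group of compound 3.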